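Stereoisomeric Ester Series: Cytotoxicity Notes on Compound 3

A few compounds are considered here, and "the series" means these few. Any claim that something is new, unique, unknown or untested is made for them only; others in the source may bear on it.

Measured so far:
compound 1 `CCO[C@@]1(CC)CCC2(CO1)[C@@H]1CCC3=C4[C@@H](CC3=O)[C@H](C(=O)OC)C[C@@]42CN(C)C1`, > 40000 nM
compound 2 `CC[C@@]1(OC)CCC2(CO1)[C@@H]1CCC3=C4[C@H](CC3=O)[C@H](C(=O)OC)C[C@@]42CN(C)C1`, > 40000 nM

In a functional assay on A549 cells (Homo sapiens) for cytotoxicity, read by MTT assay, with a stated time of 48 h (a higher number here means a weaker inhibitor, a lower number a stronger inhibitor), compound 1 returns only a limit of the assay, > 40000 nM, not a number. In this assay compound 2 likewise returns only a limit, > 40000 nM, not a number. Going by the values given here, both results therefore sit at the limit of > 40000 nM in this assay, at which 2 of the 2 values shown sit, so compound 2 stands at the limit with no resolved value, and no step between measured compounds can be described here.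

Compound 3 `CC[C@]1(OC)CCC2(CO1)[C@@H]1CCC3=C4[C@@H](CC3=O)[C@H](C(=O)OC)C[C@@]42CN(C)C1` is the next candidate. It differs from compound 2 as follows: the two compounds have the same atoms and bonds; at least one stereo element is drawn with a configuration in one of them and without one in the other: 2 of 6 stereo elements differ; a stereocentre at a saturated ring carbon is drawn S in compound 2 and R in compound 3; a stereocentre at a saturated ring carbon is drawn R in compound 2 and S in compound 3. Since compound 2 gave only a limit, no direction of change can be read from the numbers; an inversion of two ring stereocentres in an otherwise unchanged scaffold gives no basis to expect activity to emerge.

Compound 3 is therefore expected to return 60000 nM in this assay, within 15000 nM to 200000 nM, most probably again as a limit, an expected step that the limit leaves unreadable from compound 2 to compound 3.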

Compound 3, half-maximal inhibitory concentration: > 40000 nM
Compound 3 gave a limit, no number (the forecaster's own chance of this, stated with the estimate: 80%); the middle value lies beyond the limit too.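

In this assay, going by these compounds alone, compound 3 gives > 40000 nM, a limit and not a number, so no step from compound 1 or compound 2 to compound 3 can be read. The compounds shown leave open whether any compound on this shared core gives a resolved value, and so whether stereochemistry matters here.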